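A few compounds are considered here, and "the series" means these few. Any claim that something is new, unique, unknown or untested is made for them only; others in the source may bear on it.

Measured so far:
compound 1, `CCOC(=O)C1=Cc2ccccc2OC1(OCc1cn(CC(=O)Nc2ccccc2F)nn1)C(F)(F)F`, in a functional assay on MCF7 cells (Homo sapiens) for inhibition, read by MTT assay, with a stated time of 24 h; a higher number here means a weaker inhibitor, a lower number a stronger inhibitor: 42100 nM
compound 2, `CCOC(=O)C1=Cc2ccccc2OC1(OCc1cn(-c2ccc(F)c(Cl)c2)nn1)C(F)(F)F`, in this assay: 25300 nM

Compound 2 holds the lower of these two numbers, yet the step of a 1.7-fold lower number from compound 1 to compound 2 (0.22 log units; within the scatter) lies within the scatter, so the two compounds cannot be told apart. Compound 3, `CCOC(=O)C1=Cc2ccccc2OC1(OCc1cn(CC(=O)Nc2ccc(I)cc2Cl)nn1)C(F)(F)F`, differs from compound 2 by ((2-chloro-4-iodophenyl)carbamoyl)methyl in place of 3-chloro-4-fluorophenyl on an aromatic nitrogen. Among the compounds with values here, the only measured step bearing on this exchange, a 1.7-fold lower number from compound 1 to compound 2 (0.22 log units; within the scatter), is the reverse kind of swap and stayed within the scatter. A step of the same small size is therefore expected for compound 3, a 1.4-fold higher number from compound 2 to compound 3 (0.14 log units; within the scatter). Compound 3 is estimated at 35000 nM, in the range 12000 nM to 100000 nM.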

Compound 3, half-maximal inhibitory concentration: 28100 nM
Estimate against measurement, compound 3: 1.2-fold (0.10 log units) above; the range from low to high includes it.
By their numbers in this assay, from the lowest: compounds 2, 3 and 1 (each within the scatter of the next).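

Placing ((2-chloro-4-iodophenyl)carbamoyl)methyl in place of 3-chloro-4-fluorophenyl on the aromatic nitrogen gives a 1.1-fold higher number from compound 2 to compound 3 (0.05 log units; within the scatter) in this assay, so an aryl group and an amide-bearing group on this nitrogen cannot be told apart here. Changing only the group on the amide-type nitrogen, 2-chloro-4-iodophenyl in place of 2-fluorophenyl, gives a 1.5-fold lower number from compound 1 to compound 3 (0.18 log units; within the scatter) and likewise shows no readable change. No measurement is available to explain these results. From the compounds shown here alone, whether an amine or a carboxylic acid on the aromatic nitrogen would move the number beyond the scatter remains open, as does the effect of a longer chain there.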